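A few compounds are considered here, and "the series" means these few. Any claim that something is new, unique, unknown or untested is made for them only; others in the source may bear on it.

Compound 1 `O=c1[nH]/c(=C\C2CCCCC2)c(=O)[nH]/c1=C\c1cccc(Oc2ccc(F)cc2)c1`: > 1000 nM
Compound 2 `O=c1[nH]/c(=C\c2ccc([N+](=O)[O-])o2)c(=O)[nH]/c1=C\c1cccc(Oc2ccc(F)cc2)c1`: > 1000 nM

In a functional assay on NCI-H460 cells (Homo sapiens) for cytotoxicity, read by MTT assay, with a stated time of 72 h (a lower number here means a stronger inhibitor, a higher number a weaker inhibitor), compound 2 gives > 1000 nM, which is a limit and not a number. Compound 1 gives > 1000 nM, which is also a limit. So compound 2 has no exact place on the scale, and both values rest at one shared limit (the limit of > 1000 nM in this assay, at which 2 of the 2 values shown sit).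

Compound 3 `O=c1[nH]/c(=C\c2ccc(CO)o2)c(=O)[nH]/c1=C\c1cccc(Oc2ccc(F)cc2)c1` differs from compound 2 by one change: hydroxymethyl in place of nitro on an aromatic carbon. In words, hydroxymethyl replaces nitro on an aromatic carbon, turning 5-nitrofuran-2-yl into 5-(hydroxymethyl)furan-2-yl.

Going by the values given here, the only measured step is a step that the two limits leave unreadable from compound 1 to compound 2. It has no readable size, so it offers no real guide. With no sign of activity in either compound, no step beyond the scatter is expected in this assay, and another limit is the likeliest result. The expected step is a step that the limit leaves unreadable from compound 2 to compound 3. For compound 3 the estimate is 2500 nM, with an expected range of 700 nM to 10000 nM.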

Compound 3, half-maximal inhibitory concentration: 41.5 nM
Beside the measured number, compound 3's estimate is 60-fold (1.78 log units) above it; the measured number lies below the stated range.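

In this assay, hydroxymethyl in place of nitro gives an at least 24-fold lower number from compound 2 to compound 3 (1.38 log units; beyond the scatter), so the group at this carbon of the five-membered aromatic ring can separate a compound with a readable value from one without. Replacing cyclohexyl with the whole 5-(hydroxymethyl)furan-2-yl group gives an at least 24-fold lower number from compound 1 to compound 3 (1.38 log units; beyond the scatter), whereas the step between the two earlier compounds cannot be read. Both new steps are minimum sizes, since compound 1 and compound 2 each rest at a limit and not at a number: the limit of > 1000 nM in this assay, at which 2 of the 3 values shown sit.

From the compounds shown here alone, with only nitro and hydroxymethyl compared at this carbon, it remains open whether the difference comes from having hydroxymethyl or from losing nitro; a methyl group, an aminomethyl group or a carboxylic acid there would help to separate the two. Going by these compounds, it also remains open whether the same change would have a similar effect in other cell lines.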